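The compounds below may be only part of what the source reports. "The series", "measured", "known", "first", "only" and "open" are said of these compounds alone.

For the measured compounds named here, in a functional assay on SGC-7901 cells (Homo sapiens) for cytotoxicity, read by MTT assay, with a stated time of 48 h (a higher number here means a weaker inhibitor, a lower number a stronger inhibitor), compound 2 `C=C(C(=O)c1cc(OC)c(O)c(OC)c1)C(CO)C(=O)c1cc(OC)c(O)c(OC)c1` gives 67.5 ug/mL, the only actual number so far. Compound 1 `C=C(C(=O)c1cc(OC)c(O)c(OC)c1)[C@H](CO)C(=O)c1cc(OC)c(O)c(OC)c1` gives > 100 ug/mL, which is a limit of the assay and not a number. Going by the values given here, the single measured step, an at least 1.4-fold lower number from compound 1 to compound 2 (0.17 log units; that floor lies within the scatter), stays within the scatter, and it involves (the fact that one of compounds 1 and 2 is drawn with a defined configuration and the other without, at the place where they differ). Compound 3 `C=C(C(=O)c1cc(OC)c(O)c(OC)c1)[C@@H](CO)C(=O)c1cc(OC)c(O)c(OC)c1` brings the same kind of change: the two compounds have the same atoms and bonds; at least one stereo element is drawn with a configuration in one of them and without one in the other: 1 of 1 stereo elements differ; a stereocentre at a saturated chain carbon is drawn without a configuration in compound 2 and S in compound 3. With only an at least 1.4-fold lower number from compound 1 to compound 2 (0.17 log units; that floor lies within the scatter) to go on, no step beyond the scatter is expected in this assay, though a slightly lower number is possible. The expected step is a 1.2-fold lower number from compound 2 to compound 3 (0.09 log units; within the scatter). Compound 3 is estimated at 55 ug/mL, within an expected range from 25 ug/mL to 100 ug/mL.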

Compound 3, half-maximal inhibitory concentration: 34.5 ug/mL
Estimate against measurement, compound 3: 1.6-fold (0.20 log units) above; the range from low to high includes it.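

In this assay, for the compounds shown here, the configuration at the saturated chain carbon now matters, with an at least 2.8-fold lower number from compound 1 to compound 3 (0.46 log units; beyond the scatter), the first step here beyond the scatter: the fact that compounds 1 and 3 differ only in the configuration as drawn Compound 1 gives > 100 ug/mL, which is a limit of the assay and not a number, so this step is only a floor. By contrast, a 2.0-fold lower number from compound 2 to compound 3 (0.29 log units; within the scatter) stays within the scatter. From the compounds shown here alone, what compound 2, drawn without a configuration, actually contains remains open. Also open, going by these compounds, is whether the gap between the R and S forms survives with an amine or a carboxylic acid in place of the hydroxyl group.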